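Adding iodo to compound 3: an expected step

A few compounds are considered here, and "the series" means these few. Any claim that something is new, unique, unknown or untested is made for them only; others in the source may bear on it.

Among the compounds with values here, in a physicochemical assay for lipophilicity, at pH 7.4 (on this read-out higher numbers stand for higher lipophilicity and lower numbers for lower lipophilicity), compound 3 (`O=S(=O)(O)Nc1ccc(-c2nc3ccccc3s2)cc1`) gives 7.5 as the only exact number so far. For compound 1 (`Nc1ccc(-c2nc3ccccc3s2)cc1Cl`) the result is only a limit, > 3.2 and no number. For compound 2 (`Nc1ccc(-c2nc3ccccc3s2)cc1Br`) the result is also only a limit, > 2.8 and no number.

Compound 4 (`O=S(=O)(O)Nc1ccc(-c2nc3ccccc3s2)cc1I`) carries one change: iodo in place of hydrogen on an aromatic carbon and the iodo stands ortho to a sulfoamino group. Within the data shown here, the one measured halogen swap, a step that the two limits leave unreadable from compound 1 to compound 2 gives no size to borrow. With so little to lean on, only a modest rise in this assay is expected, starting from compound 3 at 7.5 and held loosely. The expected step is a number 0.50 log units higher from compound 3 to compound 4 (beyond the scatter) and it is a rough guess. For compound 4 the estimated value is 8 with an expected range from 7.2 to 9 and that range is deliberately wide.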

Compound 4, distribution coefficient: 1.9
For compound 4 the middle estimate is 6.10 log units above the measured one, and the stated range ends above it.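

In this assay, within the data shown here, iodo in place of hydrogen, ortho to a sulfoamino group, produces the first step that can be read: a number 5.60 log units lower from compound 3 to compound 4 (beyond the scatter). Among these compounds, the only earlier step, the halogen swap, cannot be read, so this result is the first to show that a change at one aromatic carbon can shift the read-out substantially. No measurement shown accounts for the direction or size of this shift.

The compounds shown leave open whether fluoro or methyl at this same position would shift the read-out in the same direction. They also leave open how much of the step is specific to iodo.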